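Trifluoromethoxy to methoxy: notes on the series

A few compounds are considered here, and "the series" means these few. Any claim that something is new, unique, unknown or untested is made for them only; others in the source may bear on it.

In a functional assay on NCI-H460 cells (Homo sapiens) for inhibition, read by MTT assay, with a stated time of 24 h, tested at 10 ug/mL (on this read-out lower numbers stand for less inhibition of growth and higher numbers for more inhibition of growth at the one concentration tested), compound 1 (`O=C(CCCCC(S)CCS)Nc1ccccc1`) gives 8.37%, compound 2 (`O=C(CCCCC(S)CCS)Nc1ccc(F)cc1`) gives 18.1% and compound 3 (`O=C(CCCCC(S)CCS)Nc1ccc(OC(F)(F)F)cc1`) gives 29.2%. Compound 3 stands highest of the three, with its gaps to both others beyond the scatter.

The next structure is compound 4 (`COc1ccc(NC(=O)CCCCC(S)CCS)cc1`). The difference is methyl in place of trifluoromethyl on an oxygen on an aromatic ring, or trifluoromethoxy to methoxy.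

No methoxy value exists yet, so only indirect evidence bears on this change. Trifluoromethoxy in place of hydrogen gave a number 20.8 percentage points higher from compound 1 to compound 3 (beyond the scatter), and trifluoromethoxy in place of fluoro gave a number 11.1 percentage points higher from compound 2 to compound 3 (beyond the scatter). Fluoro in place of hydrogen gave a number 9.7 percentage points higher from compound 1 to compound 2 (within the scatter).

On those steps, part of the gain held by compound 3 is expected to be lost, a modest drop in this assay. The expected step is a number 13.2 percentage points lower from compound 3 to compound 4 (beyond the scatter). The estimate for compound 4 is 16%, with an expected range from 5% to 30%.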

Compound 4, percent growth inhibition at one concentration: 1.43%
For compound 4 the middle estimate is 14.6 percentage points above the measured one, outside the stated range (below it).
By their numbers in this assay, from the lowest: compounds 4, 1 and 2 (each within the scatter of the next, the first and the last beyond it); then compound 3.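

At this position the oxygen on the aromatic ring does not carry the gain on its own: in this assay, methyl in place of trifluoromethyl on that oxygen gives a number 27.8 percentage points lower from compound 3 to compound 4 (beyond the scatter). Against the other two compounds, methoxy behaves differently: methoxy in place of fluoro gives a number 16.7 percentage points lower from compound 2 to compound 4 (beyond the scatter), whereas methoxy in place of hydrogen gives only a number 6.9 percentage points lower from compound 1 to compound 4 (within the scatter), so methoxy does not separate from hydrogen here. No measurement at hand accounts for the loss on going from trifluoromethyl to methyl.

The compounds shown leave open whether the higher number depends on all of the trifluoromethyl group, as difluoromethoxy or ethoxy at the same place could show. They also leave open whether a trifluoromethyl group or a nitrile on the aromatic carbon, with no oxygen, would give a number near that of compound 3.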